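Trimming the sulfonamide tail in a pyrimidinone kinase inhibitor series

The source may report more compounds than this note shows. Statements on the series, on what has been measured and on what is new or still open speak of the compounds shown alone.

Measured compounds:
- Compound 1, `CCCNS(=O)(=O)c1ccc(Nc2ncc3c(n2)N(C2CCCC2)[C@H](CC)C(=O)N3C)cc1`: 2100 nM
- Compound 2, `CCC1C(=O)N(C)c2cnc(Nc3ccc(S(=O)(=O)NCCCO)cc3)nc2N1c1ccn(C)n1`: 25800 nM
- Compound 3, `CC[C@@H]1C(=O)N(C)c2cnc(-n3ccc4cc(C(=O)NCC(C)C)ccc43)nc2N1C1CCCC1`: "not active" (no number reported)

In a functional assay on NCI-H1975 cells (Homo sapiens) for antiproliferative activity, read by CCK-8 assay, with a stated time of 72 h (a lower number here means a stronger inhibitor of growth, a higher number a weaker inhibitor of growth), compound 2 gives 25800 nM, the highest of the two numbers recorded; the nearest, compound 1, sits lower by a gap beyond the scatter, and compound 3 is recorded as "not active" (no number reported) without a single number. Compound 4, `CCC1C(=O)N(C)c2cnc(Nc3ccc(S(=O)(=O)NC)cc3)nc2N1c1ccn(C)n1`, differs from compound 2 in one place: hydrogen in place of 2-hydroxyethyl on a saturated chain carbon bound to a sulfonamide nitrogen. For the measured compounds named here, no measured pair isolates this change, so its effect is unknown. The shortened tail is expected to leave growth inhibition roughly where it stands, with any step from compound 2 to compound 4 of a 1.3-fold lower number from compound 2 to compound 4 (0.11 log units; within the scatter) expected to stay within the scatter. Compound 4 is therefore estimated at 20000 nM, in the range 6000 nM to 60000 nM.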

Compound 4, concentration for 50% growth inhibition: 18800 nM
Compound 4: the middle estimate sits 1.1-fold (0.03 log units) above what was measured, and the stated range covers the measured number.
By their numbers in this assay, from the lowest: compound 1; then compounds 4 and 2 (each within the scatter of the next).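

In this assay, exchanging 3-hydroxypropyl for methyl on the sulfonamide nitrogen gives a 1.4-fold lower number from compound 2 to compound 4 (0.14 log units; within the scatter) and so leaves compound 2 and compound 4 indistinguishable. For the compounds shown here, this is the first direct reading of this position: in this pair, growth inhibition does not depend on keeping the 3-hydroxypropyl chain. No supporting measurement is available to explain this result. On these data alone, whether an amine, a carboxylic acid or a longer chain in place of the 3-hydroxypropyl would shift growth inhibition remains open.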